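Moving the chlorine on the aryl group of compound 1

This account rests on a few compounds, and the source may have more. Where it says the series, first, only, none or still open, it means among the compounds named here.

Within the data shown here, in a functional assay on MCF7 cells (Homo sapiens) for antiproliferative activity, read by MTT assay, with a stated time of 72 h (on this read-out higher numbers stand for weaker inhibition and lower numbers for stronger inhibition), compound 1 `C#CCSc1nc(Sc2nnnn2CCN(C)C)c(C#N)c(-c2ccc(Cl)cc2)n1` gives 6180 nM and compound 2 `C#CCSc1nc(Sc2nccs2)c(C#N)c(-c2ccc(Cl)cc2)n1` gives 3230 nM, so compound 1 stands within the scatter of the only other measured compound. Among the measured compounds shown here, the single measured step, a 1.9-fold lower number from compound 1 to compound 2 (0.28 log units; within the scatter), concerns the group on a sulfur, not the aryl group. Compound 3 `C#CCSc1nc(Sc2nnnn2CCN(C)C)c(C#N)c(-c2cccc(Cl)c2)n1` keeps the sulfur group of compound 1 and differs only in the position of the chlorine: 3-chlorophenyl in place of 4-chlorophenyl on an aromatic carbon. For the measured compounds named here, no measured pair changes the chlorophenyl group, so the data give no direct guide to this change, and no step beyond the scatter is expected in this assay. The expected step is a 1.0-fold lower number from compound 1 to compound 3 (0.01 log units; within the scatter). For compound 3 the estimate is 6000 nM, with an expected range of 2500 nM to 14000 nM.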

Compound 3, half-maximal inhibitory concentration: 4120 nM
Compound 3: middle estimate off by 1.5-fold (0.16 log units), on the high side; low and high end bracket the measured number.
By their numbers in this assay, from the lowest: compounds 2, 3 and 1 (each within the scatter of the next).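

Among these compounds, this pair is the first to vary the chlorophenyl group on the aromatic carbon next to the ring nitrogen: with 3-chlorophenyl in place of 4-chlorophenyl, there is a 1.5-fold lower number from compound 1 to compound 3 (0.18 log units; within the scatter) in this assay. With the 1-(2-(dimethylamino)ethyl)-1H-tetrazol-5-yl group held on the sulfur, this assay therefore does not separate the two chlorine positions. Nothing available bears on the reason for this result.

It remains open whether the two chlorine positions also read alike with 1,3-thiazol-2-yl on the sulfur, as only one sulfur group is shown with 3-chlorophenyl. Also open, on these data alone, is how this position responds to a different aryl group, such as unsubstituted phenyl or a methoxyphenyl, or to a ring bearing an amine or a carboxylic acid.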